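The compounds below may be only part of what the source reports. "The series", "measured", "known", "first", "only" and "open" are said of these compounds alone.

Of the compounds shown here, two have so far been measured in an assay on isolated protein for binding affinity to sphingosine 1-phosphate receptor 2 (Homo sapiens), read by surface plasmon resonance; on this read-out higher numbers stand for weaker binding and lower numbers for tighter binding. Compound 1 `COc1ccc(-c2cc(NNC(=O)Nc3cc(Cl)nc(OC(C)C)c3)nc3c2cnn3C)cc1` gives 2320 nM in this assay, and compound 2 `Cn1ncc2c(-c3ccc(F)cc3)cc(NNC(=O)Nc3cc(Cl)nc(OCCF)c3)nc21` gives 2790 nM; these two numbers lie within the usual scatter of each other, so on this read-out the two compounds cannot be told apart. Compound 3 `CCCOc1cc(NC(=O)NNc2cc(-c3ccc(OC)cc3)c3cnn(C)c3n2)cc(Cl)n1` has not yet been measured. It differs from compound 1 in one place: propyl in place of isopropyl on an oxygen on an aromatic ring. The two have the same atoms, joined differently, and only the arrangement of the chain on that oxygen changes. Among the compounds with values here, no measured pair shows what such a change does here, so the expectation rests on the structures alone. Only a small step is expected, a 1.1-fold higher number from compound 1 to compound 3 (0.03 log units; within the scatter), in no clear direction and not beyond the scatter. Compound 3 is therefore estimated to give 2500 nM, with a range from 1000 nM to 6000 nM.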

Compound 3, dissociation constant: 3140 nM
For compound 3 the middle estimate is 1.3-fold (0.10 log units) below the measured one, and the stated range covers the measured number.
By their numbers in this assay, from the lowest: compounds 1, 2 and 3 (each within the scatter of the next).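

Replacing isopropyl with propyl on this oxygen gives a 1.4-fold higher number from compound 1 to compound 3 (0.13 log units; within the scatter) in this assay. Within the data shown here, this is the first pair here that differs in only one place, and it shows that rearranging the chain while keeping the same atoms produces no change that this read-out can separate from ordinary scatter. No independent measurement bears on why the two compounds cannot be told apart.

Going by these compounds, this single comparison covers only two arrangements of the same atoms, so it remains open whether a longer chain such as butyl, a ring such as cyclopropyl, or an amine on this oxygen would give a clearly different number. It is also unknown whether changes elsewhere on the core of compound 1 could move binding beyond the scatter.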